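The compounds below may be only part of what the source reports. "The series", "measured", "known", "first", "only" and "open" are said of these compounds alone.

Measured so far in a functional assay on the whole organism for positive allosteric modulation, with Rattus norvegicus as the target; on this read-out lower numbers stand for an effect already at smaller amounts and higher numbers for an effect only at larger amounts of compound:
compound 1 `Cc1nn(C)c2c1C(c1cccc(C(F)(F)F)c1)=NCCN2`, 0.63 mg/kg
compound 2 `Cc1nn(C)c2c1C(c1cccc(Br)c1)=NCCN2`, 0.63 mg/kg

Compound 2 sits level with compound 1 at the digits shown; the step of no change at the digits printed from compound 1 to compound 2 (within the scatter) stays within the scatter, and it is the only measured step. Compound 3 `CCc1nn(C)c2c1C(c1cccc(Br)c1)=NCCN2` differs from compound 2 by methyl in place of hydrogen on a saturated chain carbon bound to an aromatic carbon. For the measured compounds named here, the measured step concerns a different place, a substituent on the aromatic ring, so no step among the measured compounds bears directly on this change; small growth of this kind is expected to leave this assay unchanged beyond the scatter. Compound 3 is therefore estimated at 0.63 mg/kg, expected between 0.3 mg/kg and 1.3 mg/kg, a step of no change at the digits printed from compound 2 to compound 3 (within the scatter).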

Compound 3, minimum effective dose: 1.25 mg/kg
Beside the measured number, compound 3's estimate is 2.0-fold (0.30 log units) below it; the measured number falls inside the stated range.
By their numbers in this assay, from the lowest: compounds 1, 2 and 3 (each within the scatter of the next).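

For the compounds shown here, earlier compounds differed only in the substituent on the aromatic ring, so this is the first measured look at the other position, where methyl becomes ethyl on a saturated chain carbon bound to an aromatic carbon. In this assay, the result is a 2.0-fold higher number from compound 2 to compound 3 (0.30 log units; within the scatter), so adding this one carbon gives no difference that can be separated from the scatter. Nothing available explains this result.

On these data alone, a longer chain such as propyl, a cyclopropyl ring or an amine at this position remains open. So does whether the same step holds with trifluoromethyl on the aromatic ring.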